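Bromo in place of methoxy: compound 3 to compound 4

The source may report more compounds than this note shows. Statements on the series, on what has been measured and on what is new or still open speak of the compounds shown alone.

Measured in a physicochemical assay for solubility, using the shake flask method, in simulated intestinal fluid, measured as kinetic solubility, with a stated time of 2 h, at 25 degrees C, at pH 6.5 (a lower number here means a less soluble compound, a higher number a more soluble compound), so far:
- compound 1 `Cc1noc(-c2nc(C)c3c(c2N)C(=O)N(Cc2ccc(F)cc2)C3=O)n1` gives < 5000 nM as a limit
- compound 2 `Cc1noc(-c2nc(C)c3c(c2N)C(=O)N(Cc2ccc(-n4cccn4)cc2)C3=O)n1` gives < 5000 nM as a limit
- compound 3 `COc1ccc(CN2C(=O)c3c(C)nc(-c4nc(C)no4)c(N)c3C2=O)cc1` gives < 5000 nM as a limit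

Compound 3 has no numerical value, only < 5000 nM as a limit. The other two measured compounds offer no number either, and the whole set stands as the limit of < 5000 nM in this assay, at which 3 of the 3 values shown sit, with nothing further to rank them.

Compound 4 `Cc1noc(-c2nc(C)c3c(c2N)C(=O)N(Cc2ccc(Br)cc2)C3=O)n1` has bromo in place of methoxy on an aromatic carbon, so that 4-methoxybenzyl becomes 4-bromobenzyl, with the difference counted as bromo in place of methoxy on an aromatic carbon and the rest of the structure unchanged.

Going by the values given here, three measured steps bear on this change. Among the compounds with values here, the first is a step that the two limits leave unreadable from compound 1 to compound 3 and the second is a step that the two limits leave unreadable from compound 2 to compound 3 and both involve the methoxy compound. The third is a step that the two limits leave unreadable from compound 1 to compound 2 and it concerns the same substituent place. None of them has a readable size or direction, so none can be carried over.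

In this assay no step beyond the scatter is expected, and compound 4 will most likely report a limit as well. The expected change is a step that the limit leaves unreadable from compound 3 to compound 4 as an estimate only. For compound 4 the estimated value is 2500 nM with an expected range from 800 nM to 5000 nM as its upper end.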

Compound 4, solubility: < 5000 nM
Compound 4: no number, only a limit; the forecaster's own chance of this, stated with the estimate: 85%; the middle value does not contradict the limit.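

In this assay compound 4 gives < 5000 nM, a limit and not a number. The steps joining compound 4 to compound 1, compound 2 and compound 3 cannot be read, and the set offers a single level: the limit of < 5000 nM in this assay, at which 4 of the 4 values shown sit. As far as these compounds go, whether fluoro, 1H-pyrazol-1-yl, methoxy and bromo differ at all on this read-out stays open.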